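Methoxy to fluoro on the benzyl ring of compound 2

The source may report more compounds than this note shows. Statements on the series, on what has been measured and on what is new or still open speak of the compounds shown alone.

Compound 2 `COc1ccc(CN2CCC(C(=O)Nc3ccc(CNc4nc(N(C)C)nc5cc(C)ccc45)cc3)CC2)cc1` was tested in a functional assay on SV5A8 cells (Homo sapiens) for cytotoxicity; on this read-out higher numbers stand for weaker inhibition and lower numbers for stronger inhibition. In this assay compound 2 gives > 6180 nM, which is a limit of the assay rather than a number. Compound 1 `Cc1ccc2c(NCc3ccc(NC(=O)C4CCN(Cc5cccc(F)c5)CC4)cc3)nc(N(C)C)nc2c1` differs from it on a saturated chain carbon bound to an amine nitrogen in a ring, carrying 3-fluorophenyl where compound 2 carries 4-methoxyphenyl. In this assay compound 1 gives > 4170 nM, also a limit. The step that the two limits leave unreadable from compound 1 to compound 2 cannot be sized because the limit of > 4170 nM in this assay, at which 1 of the 2 values shown sits, and the limit of > 6180 nM in this assay, at which 1 of the 2 values shown sits, both sit at the edge of what the assay reports. Compound 3 `Cc1ccc2c(NCc3ccc(NC(=O)C4CCN(Cc5ccc(F)cc5)CC4)cc3)nc(N(C)C)nc2c1` is not yet measured; its change from compound 2 is fluoro in place of methoxy on an aromatic carbon. For the measured compounds named here, no measured step covers this change, and the one step available is unreadable, so no shift beyond the scatter can be expected in either direction; with both measured compounds at limits, a limit is also the most likely outcome for compound 3. Compound 3 is expected to give 6000 nM in this assay, between 2000 nM and 20000 nM. The expected step of an at least 1.0-fold lower number from compound 2 to compound 3 (0.01 log units; that floor lies within the scatter) is therefore close to nothing.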

Compound 3, half-maximal inhibitory concentration: > 4820 nM
Compound 3: only a limit was reported; the forecaster's own chance of this, stated with the estimate: 80%; the middle value lies beyond the limit too.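

In this assay compound 3 gives > 4820 nM, which is a limit and not a number. For the compounds shown here, compound 1, compound 2 and compound 3 all stand at limits, so no step among them can be read. Still open, on these data alone, is what number each compound would give in this assay, and whether swapping methoxy for fluoro changes it at all.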